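Chain substituent at the alpha carbon: carboxy to methylsulfanyl

This account rests on a few compounds, and the source may have more. Where it says the series, first, only, none or still open, it means among the compounds named here.

Compound 3 `O=C(O)CC[C@H](NC(=O)CN(c1nc(Cl)nc2[nH]cnc12)C1CC1)C(=O)O` gives 33.3% in a functional assay on the whole organism (Tail, strain ICR) with Mus musculus as the target, in the tail flick test, with a stated time of 60 min, at a dose of 25 umol/kg by the oral route (a lower number here means a weaker effect, a higher number a stronger effect of the compound at the dose given), the second highest of three numbers: nearest stands compound 1 `CSCC[C@H](NC(=O)CN(c1nc(Cl)nc2[nH]cnc12)C1CC1)C(=O)OCc1ccccc1` with 30.8%, within the scatter, and furthest compound 2 `C[C@H](NC(=O)CN(c1nc(Cl)nc2[nH]cnc12)C1CC1)C(=O)O` with 44.6%, beyond it. The one step among these compounds that differs in a single place, a number 11.3 percentage points lower from compound 2 to compound 3 (beyond the scatter), concerns the carboxymethyl group that compound 4 again loses. Compound 4 `CSCC[C@H](NC(=O)CN(c1nc(Cl)nc2[nH]cnc12)C1CC1)C(=O)O` differs from compound 3 by methylsulfanyl in place of carboxy on a saturated chain carbon, three bonds along the chain from an amide-type nitrogen and a carbonyl carbon. For the measured compounds named here, no measured pair shows carboxy against methylsulfanyl directly; compound 1 carries the methylsulfanyl group with a benzyl ester and gives 30.8%, a number within the scatter of compound 3. Taking away the carboxy group is expected to undo part of the drop seen from compound 2 to compound 3, so for compound 4 a modest rise, a number 6.7 percentage points higher from compound 3 to compound 4 (within the scatter), is expected in this assay. Compound 4 is therefore estimated at 40%, with a range from 25% to 55%.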

Compound 4, a percentage reported as activity, at one dose (the size of the read-out at that dose, not a potency): 22.8%
The estimate for compound 4 lay 17.2 percentage points above the measured number; the whole stated range lies above it.
By their numbers in this assay, from the lowest: compounds 4, 1 and 3 (each within the scatter of the next, the first and the last beyond it); then compound 2.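

In this assay the direct exchange of carboxy for methylsulfanyl gives a number 10.5 percentage points lower from compound 3 to compound 4 (beyond the scatter) and so takes the number further down rather than back towards compound 2. Against a number 11.3 percentage points lower from compound 2 to compound 3 (beyond the scatter) seen with carboxymethyl, the (methylsulfanyl)methyl group in place of hydrogen gives a number 21.8 percentage points lower from compound 2 to compound 4 (beyond the scatter) as the larger fall at this place, so both chains tested on this carbon lie under the hydrogen of compound 2. Hydrogen in place of benzyl on an oxygen next to a carbonyl group gives a number 8 percentage points lower from compound 1 to compound 4 (within the scatter) and leaves the free acid and its benzyl ester not told apart at this dose.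

From the compounds shown here alone, how an amine, a hydroxyl group or a longer chain would fare on this carbon stays open, as does the benzyl ester of compound 2. Nothing at hand offers a reason for these steps.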